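This account rests on a few compounds, and the source may have more. Where it says the series, first, only, none or still open, it means among the compounds named here.

Measured compounds:
compound 1 `CCc1ccc(-c2ccc(-c3ccc(C(=N)N)cc3)o2)cc1` gives 312 nM in an assay on isolated protein for inhibition of ribosyldihydronicotinamide dehydrogenase [quinone] (Homo sapiens), read by spectrophotometry, with a stated time of 1 min; a higher number here means a weaker inhibitor, a lower number a stronger inhibitor
compound 2 `N=C(N)c1ccc(-c2ccc(-c3cccc(F)c3)o2)cc1` gives 111 nM in this assay

Compound 2 holds the lowest number of the two; its nearest neighbour, compound 1, sits higher by a margin beyond the scatter. Compound 3 `N=C(N)c1ccc(-c2ccc(-c3ccc(Br)cc3)o2)cc1` differs from compound 2 by 4-bromophenyl in place of 3-fluorophenyl on an aromatic carbon. For the measured compounds named here, no measured pair covers this change, so the expected step of a 1.4-fold higher number from compound 2 to compound 3 (0.13 log units; within the scatter) is set small, with no clear direction beyond the scatter. Compound 3 is therefore estimated at 150 nM in this assay, with a range from 50 nM to 500 nM.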

Compound 3, half-maximal inhibitory concentration: 185 nM
For compound 3 the middle estimate is 1.2-fold (0.09 log units) below the measured one; the range from low to high includes it.
By their numbers in this assay, from the lowest: compounds 2, 3 and 1 (each within the scatter of the next, the first and the last beyond it).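

On the aromatic carbon next to the ring oxygen, 4-bromophenyl in place of 3-fluorophenyl gives a 1.7-fold higher number from compound 2 to compound 3 (0.22 log units; within the scatter), so this exchange of aryl groups is not resolved by the assay. Bromo in place of ethyl on an aromatic carbon gives a 1.7-fold lower number from compound 1 to compound 3 (0.23 log units; within the scatter), so compound 3 cannot be separated from either neighbour. Nothing at hand bears on the reason for these results. Open, as far as these compounds go, is whether the halogen or its ring place matters, which 4-fluorophenyl could separate. Also open, from the compounds shown here alone, is whether an amine or a carboxylic acid on that phenyl moves the number beyond the scatter.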